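The compounds below may be only part of what the source reports. "The series", "measured", "known", "first", "only" and "open" are said of these compounds alone.

Compound 1 `C#CCNC(=O)/C(C)=C(\C)c1ccc(Br)cc1`: 500 mg/kg
Compound 2 `C=CCNC(=O)/C(C)=C(\C)c1ccc(Br)cc1`: 500 mg/kg
Compound 3 `C/C(C(=O)NC1CC1)=C(/C)c1ccc(Br)cc1`: 600 mg/kg

Of the compounds shown here, three sharing one core have been tested in a toxicity assay on the whole organism (strain Icem-CET (SPF Caw)) for cytotoxicity, with Mus musculus as the target; a lower number here means that less compound is needed, a higher number that more compound is needed for the effect. Compound 3, with a cyclopropyl on the amide nitrogen, sits within the scatter of the other two: the step of a 1.2-fold higher number from compound 1 to compound 3 (0.08 log units; within the scatter) and the step of a 1.2-fold higher number from compound 2 to compound 3 (0.08 log units; within the scatter) are both too small to count, and likewise no change at the digits printed from compound 1 to compound 2 (within the scatter). So far, then, swapping the group on the amide nitrogen among propargyl, allyl and cyclopropyl has moved nothing in this assay.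

Compound 4 `C/C(C(=O)NC1CC1)=C(/C)c1ccc(F)cc1` keeps the cyclopropyl amide of compound 3 and alters the aromatic ring instead: fluoro in place of bromo on an aromatic carbon. Among the measured compounds shown here, none of the measured steps touches the halogen on the ring, so there is no direct guide for this change. With the three known values so close together, the working expectation is that compound 4 behaves like compound 3, giving no change at the digits printed from compound 3 to compound 4 (within the scatter), a step not beyond the scatter. Compound 4 is therefore estimated at 600 mg/kg, with a likely range from 350 mg/kg to 1000 mg/kg.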

Compound 4, dose for half-maximal effect: 200 mg/kg
Compound 4: the middle estimate sits 3.0-fold (0.48 log units) above what was measured; the whole stated range lies above it.
By their numbers in this assay, from the lowest: compound 4; then compounds 1, 2 and 3 (each within the scatter of the next).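

In this assay, the halogen on the aromatic ring matters where the group on the amide nitrogen did not: fluoro in place of bromo means less compound is needed for the effect (a 3.0-fold lower number from compound 3 to compound 4 (0.48 log units; beyond the scatter)). Among these compounds, this ring position, para to a large group, is the only place where a single swap moves the number beyond the scatter, even though the change only exchanges one halogen for another. Nothing available here accounts for the difference between the bromo and fluoro compounds.

As far as these compounds go, this step rests on the cyclopropyl amide alone, so it remains open whether fluoro has the same effect alongside the propargyl or allyl amide. Also open, from the compounds shown here alone, is how chloro, methoxy or an amine at the same ring position would compare.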